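Swapping bromo for ethoxy on a shared triazine-free core

This account rests on a few compounds, and the source may have more. Where it says the series, first, only, none or still open, it means among the compounds named here.

Of the compounds shown here, three built on one shared core have been tested so far in a functional assay on the whole organism with Rattus norvegicus as the target, at a dose of 20 mg/kg by the intraperitoneal route; on this read-out higher numbers stand for more inhibition at the one dose given (going by the name of the read-out) and lower numbers for less inhibition. Compound 1, `Nc1nc(N)nc(-c2ccccc2Br)n1`, gives 26% in this assay, which places it second highest of the three numbers. The highest belongs to compound 2, `COc1ccc(Br)cc1-c1nc(N)nc(N)n1`, which gives 49% in this assay, a number higher than that of compound 1 by more than the usual scatter. The lowest belongs to compound 3, `CS(=O)(=O)c1cccc(-c2nc(N)nc(N)n2)c1`, which gives -6% in this assay, a number lower than that of compound 1 by more than the usual scatter.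

The next compound to consider is compound 4, `CCOc1ccccc1-c1nc(N)nc(N)n1`, which has not yet been measured. It differs from compound 1 in one place: ethoxy in place of bromo on an aromatic carbon. Going by the values given here, no measured pair shows this exact exchange, so the direction of the step cannot be read off from earlier results. Compound 2 carries a methoxy group alongside its bromo, yet it also carries the bromo at a different place, so its value of 49% in this assay offers only loose guidance.

Because compound 1 gives 26% in this assay, the step from compound 1 to compound 4 is expected to be small, within the scatter, at a number 4 percentage points higher from compound 1 to compound 4 (within the scatter). Compound 4 is therefore estimated to give 30% in this assay, within a range from 5% to 55%.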

Compound 4, a percentage reported as inhibition, in the whole organism at one dose (the size of the read-out at that dose, not a potency): -5%
The estimate for compound 4 lay 35 percentage points above the measured number, and the stated range ends above it.
By their numbers in this assay, from the lowest: compounds 3 and 4 (each within the scatter of the next); then compound 1; then compound 2.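

In this assay, going by these compounds alone, the exchange of bromo for ethoxy on an aromatic carbon, ortho to a group of 8 heavy atoms, is the only change at a single place that can be read so far, and the step is large: a number 31 percentage points lower from compound 1 to compound 4 (beyond the scatter). This shows that the position does not treat all groups alike, since replacing the single bromine atom with an ethoxy group of 3 heavy atoms removes the inhibition seen for compound 1 at this one dose. No measurement at hand explains the drop.

One exchange cannot show whether the loss follows the oxygen attached to the aromatic ring, the two carbons of the ethoxy group, or the absence of bromo. A chlorine atom, a hydroxyl group or an amine at this same place on the core of compound 1 would help to separate these possibilities, and a longer chain would show whether the number stays low as the group grows.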